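Compound 3: Removing the Methyl Group from Compound 2

This account rests on a few compounds, and the source may have more. Where it says the series, first, only, none or still open, it means among the compounds named here.

In a functional assay on MCF7 cells (Homo sapiens) for inhibition, read by CCK-8 assay, with a stated time of 48 h (on this read-out lower numbers stand for stronger inhibition and higher numbers for weaker inhibition), compound 1 `COc1cc(-c2ccnc3cc(-c4c[nH]c5ccccc45)nn23)cc(OC)c1OC` gives 85 nM and compound 2 `COc1cc(-c2ccnc3cc(-c4ccc(C)cc4)nn23)cc(OC)c1OC` gives 47 nM. Within the data shown here, these two numbers lie within the scatter of each other, so compound 2 cannot be separated from compound 1, its only measured neighbour. Compound 3 `COc1cc(-c2ccnc3cc(-c4ccccc4)nn23)cc(OC)c1OC` differs from compound 2 by one change, hydrogen in place of methyl on an aromatic carbon. Among the measured compounds shown here, the only measured step that bears on this is a 1.8-fold lower number from compound 1 to compound 2 (0.26 log units; within the scatter), which exchanges 1H-indol-3-yl for 4-methylphenyl. For the measured compounds named here, no measured step isolates the methyl itself, but that wider exchange stayed within the scatter. Accordingly, a 1.2-fold higher number from compound 2 to compound 3 (0.07 log units; within the scatter) is expected to stay within the scatter as well, with no firm direction. The estimated value for compound 3 is 55 nM, expected to fall between 22 nM and 140 nM.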

Compound 3, half-maximal inhibitory concentration: 254 nM
Beside the measured number, compound 3's estimate is 4.6-fold (0.66 log units) below it, outside the stated range (above it).
By their numbers in this assay, from the lowest: compounds 2 and 1 (each within the scatter of the next); then compound 3.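

In this assay, the loss of a single methyl para to a large group gives a 5.4-fold higher number from compound 2 to compound 3 (0.73 log units; beyond the scatter) and so shows that this position responds to the change from 4-methylphenyl to phenyl, which the earlier step between two larger groups could not reveal. Phenyl also separates from 1H-indol-3-yl with a 3.0-fold higher number from compound 1 to compound 3 (0.48 log units; beyond the scatter) even though 4-methylphenyl could not be told apart from that group, so compound 3 alone stands apart among the three. Nothing in the data shown accounts for this difference.

The compounds shown leave open whether another group in this place, such as ethyl, methoxy, chlorine or an amine, would match compound 2 or compound 3. They also leave open whether a methyl elsewhere on the phenyl ring would give the same result.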